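Propyl in Place of 4-Methylphenyl on a Shared Core

This account rests on a few compounds, and the source may have more. Where it says the series, first, only, none or still open, it means among the compounds named here.

Of the compounds shown here, two with a common core have so far been tested in a functional assay on HeLa cells (Homo sapiens) for cytotoxicity, read by sulforhodamine B assay, with a stated time of 48 h; on this read-out lower numbers stand for stronger inhibition and higher numbers for weaker inhibition. Compound 1 `CC(=O)OC[C@H]1O[C@@H](n2cc(CN3C(=O)/C(=C\c4ccc(C)cc4)c4ccccc43)nn2)[C@H](OC(C)=O)[C@@H](OC(C)=O)[C@@H]1OC(C)=O` stands at the edge of what the test can report: its value, > 100000 nM, is a limit of the assay and not a measured number. Compound 2 `CC(=O)OC[C@H]1O[C@@H](n2cc(CN3C(=O)/C(=C/c4ccco4)c4ccccc43)nn2)[C@H](OC(C)=O)[C@@H](OC(C)=O)[C@@H]1OC(C)=O` does give a number in this assay, 29900 nM. These two differ in more than one place, so the values are shown side by side and nothing further is drawn from the pair.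

Compound 3 `CCC/C=C1\C(=O)N(Cc2cn([C@@H]3O[C@H](COC(C)=O)[C@@H](OC(C)=O)[C@H](OC(C)=O)[C@H]3OC(C)=O)nn2)c2ccccc21` has not yet been measured. It differs from compound 1 in a single way: propyl in place of 4-methylphenyl on a double-bonded chain carbon bound to a double-bonded ring carbon. Because compound 1 sits at the limit of > 100000 nM in this assay, at which 1 of the 2 values shown sits, the starting point for this step is itself only a boundary. The expected step is a step that the limit leaves unreadable from compound 1 to compound 3, which is no change beyond the usual scatter, and it is likely that this assay again reports only a limit. The estimated value for compound 3 is 150000 nM, with an expected range from 40000 nM to 500000 nM.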

Compound 3, half-maximal inhibitory concentration: 46300 nM
Compound 3: middle estimate off by 3.2-fold (0.51 log units), on the high side, and the stated range covers the measured number.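

Replacing 4-methylphenyl with propyl on a double-bonded chain carbon bound to a double-bonded ring carbon has an effect that can be read in this assay, with an at least 2.1-fold lower number from compound 1 to compound 3 (0.33 log units; beyond the scatter). The position therefore responds to this change: an open chain with no ring and fewer heavy atoms brings the read-out within measurable range, although compound 3, at 46300 nM, still shows a high number, which on this read-out means weak inhibition. The full size of the step cannot be known, because the value for compound 1 is a limit of the assay and not a measured number: the limit of > 100000 nM in this assay, at which 1 of the 3 values shown sits.

The compounds shown do not tell whether the difference comes from losing the aromatic ring or from the smaller group, a question that cyclohexyl, a ring that is not aromatic, could help to separate. They also leave open whether a longer chain such as hexyl, or a chain ending in an amine or a carboxylic acid, would take the number lower or higher than propyl does.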